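The source may hold more compounds than are shown below. What is called first, only, known or untested is meant among the compounds shown, and "the series" means these compounds.

In a functional assay with Alpha-1D adrenergic receptor (Homo sapiens) as the target, read by calcium flux (a higher number here means a larger maximal response, a lower number a smaller maximal response), the three measured compounds give these results:
Compound 1 `CC(C)n1ncnc1-c1ccccc1NCC1=NCCN1` gives 37%.
Compound 2 `Cc1n[nH]c(-c2ccccc2NCC2=NCCN2)n1` gives 0%.
Compound 3 `Cn1ncnc1-c1ccccc1NCC1=NCCN1` gives 116%.

Compound 3 stands highest of the three: a number 79 percentage points higher from compound 1 to compound 3 (beyond the scatter) and a number 116 percentage points higher from compound 2 to compound 3 (beyond the scatter), both well beyond the scatter. Compound 4 `c1ccc(-c2nc[nH]n2)c(NCC2=NCCN2)c1` differs from compound 3 by 1H-1,2,4-triazol-3-yl in place of 1-methyl-1H-1,2,4-triazol-5-yl on an aromatic carbon. The step from compound 2 to compound 3 bears on this most, since compound 2 also carries a triazole with a ring hydrogen instead of a methyl on a ring nitrogen, and that step was large. Compound 4 is therefore expected to fall steeply, by roughly a number 96 percentage points lower from compound 3 to compound 4 (beyond the scatter). The maximal response of compound 4 in this assay is estimated at 20%, with a range from 0% to 60%.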

Compound 4, largest response reached (reported as maximal response), in percent of the reference or control that the assay uses: 123%
The estimate for compound 4 lay 103 percentage points below the measured number; measured number outside the range, above it.
By their numbers in this assay, from the lowest: compound 2; then compound 1; then compounds 3 and 4 (each within the scatter of the next).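

In this assay the triazole with a ring hydrogen holds up: a number 7 percentage points higher from compound 3 to compound 4 (within the scatter) means the two compounds cannot be told apart, so a methyl on a ring nitrogen is not needed for a full response. The ring hydrogen therefore does not account for compound 2, and a number 123 percentage points higher from compound 2 to compound 4 (beyond the scatter) goes with the one methyl on the triazole carbon in 3-methyl-1H-1,2,4-triazol-5-yl. Nothing measured here explains that loss. On these data alone, whether an ethyl or an amine at that ring carbon would also lower the response remains open.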